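The compounds below may be only part of what the source reports. "The series", "measured", "known", "first", "only" and "open" are said of these compounds alone.

Going by the values given here, only two compounds have been measured in a functional assay on BT-549 cells (Homo sapiens) for antiproliferative activity, read by MTT assay, with a stated time of 48 h; a lower number here means a stronger inhibitor, a higher number a weaker inhibitor: compound 1 `CCN1C(=O)C(O)(Cc2nnn[nH]2)c2ccccc21` and compound 2 `CN1C(=O)C(O)(Cc2nnn[nH]2)c2cc(Br)ccc21`. Compound 1 gives > 100000 nM, which is a limit of the assay and not a number. Compound 2 gives > 100000 nM, which is also a limit and not a number. Compound 2 therefore stands on (the limit of > 100000 nM in this assay, at which 2 of the 2 values shown sit). Compound 3 `CCN1C(=O)C(O)(Cc2nnn[nH]2)c2cc(Br)ccc21` differs from compound 2 by a single change, methyl in place of hydrogen on a saturated chain carbon bound to an amide-type nitrogen in a ring, or methyl to ethyl. Among the compounds with values here, no measured step in this assay gauges this change, and none beyond the scatter is expected. That expectation rests on compound 2 at > 100000 nM, a limit of the assay. The expected change, a number no higher from compound 2 to compound 3 (the limit leaves the size open), is therefore small, and another limit is likely. Compound 3 is estimated at 100000 nM, with an expected range of 40000 nM to 200000 nM.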

Compound 3, half-maximal inhibitory concentration: > 100000 nM
Compound 3: no number, only a limit; the forecaster's own chance of this, stated with the estimate: 80%; the middle value sits exactly at the limit.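

In this assay compound 3 gives > 100000 nM, a limit of the assay and not a number, so neither its step from compound 1 nor its step from compound 2 can be read. The compounds shown leave open whether any change to the shared core would give a measurable value: the limit of > 100000 nM in this assay, at which 3 of the 3 values shown sit.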